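Swapping Fluoro for Hydroxy on an Isothiocyanate Chain Series

The source may hold more compounds than are shown below. What is called first, only, known or untested is meant among the compounds shown, and "the series" means these compounds.

Of the compounds shown here, three built on one shared core have been tested in a functional assay on A549 cells (Homo sapiens) for inhibition, read by CCK-8 assay, with a stated time of 72 h, tested at 1 uM; a lower number here means a weaker effect, a higher number a stronger effect of the compound at the concentration tested. Compound 1 `CN(C)C(=O)c1cc2cnc(Nc3ccc(C(=O)NCCCN=C=S)cc3F)nc2n1C1CCCC1` gives 16.7%. Compound 2 `CN(C)C(=O)c1cc2cnc(Nc3ccc(C(=O)NCCCCCN=C=S)cc3F)nc2n1C1CCCC1` gives -1.6%, the lowest of the three numbers. Compound 3 `CN(C)C(=O)c1cc2cnc(Nc3ccc(C(=O)NCCCCCCCN=C=S)cc3F)nc2n1C1CCCC1` gives 0.05%. The measured steps all concern the length of the chain that carries the isothiocyanate: a number 18.3 percentage points lower from compound 1 to compound 2 (beyond the scatter) and a number 16.7 percentage points lower from compound 1 to compound 3 (beyond the scatter), while a number 1.7 percentage points higher from compound 2 to compound 3 (within the scatter).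

Compound 4 `CN(C)C(=O)c1cc2cnc(Nc3ccc(C(=O)NCCCCCN=C=S)cc3O)nc2n1C1CCCC1` differs from compound 2 in only one place: hydroxy in place of fluoro on an aromatic carbon. For the measured compounds named here, none of the measured steps involves a change of this kind; all three alter the chain, and no compound carrying a hydroxy at that position has been measured. The data thus give no pointer in either direction, and the expectation is a step that stays within the scatter, with a wide range to allow for the untested change. Compound 4 is expected to give 2%, between -10% and 16%, which means an estimated a number 3.6 percentage points higher from compound 2 to compound 4 (within the scatter).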

Compound 4, a percentage reported as inhibition, at one concentration (the size of the read-out at that concentration, not a potency): 23.1%
The estimate for compound 4 lay 21.1 percentage points below the measured number; the whole stated range lies below it.
By their numbers in this assay, from the lowest: compounds 2 and 3 (each within the scatter of the next); then compounds 1 and 4 (each within the scatter of the next).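

The aromatic carbon carrying the fluoro turns out to matter: in this assay, hydroxy in place of fluoro gives a number 24.7 percentage points higher from compound 2 to compound 4 (beyond the scatter), with the isothiocyanate chain left unchanged. The earlier steps shown here altered only that chain, so they said nothing about this position; here, exchanging one heavy atom for another, while adding a hydrogen-bond donor and a hydrogen-bond acceptor, is enough to produce a step beyond the scatter. No measurement available here explains why the number rises.

As far as these compounds go, whether hydroxy has a similar effect on the chains of compound 1 and compound 3 remains open. So does what a methoxy, an amine or a plain hydrogen on the same aromatic carbon would give, which would help show what this position tolerates.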